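This account rests on a few compounds, and the source may have more. Where it says the series, first, only, none or still open, it means among the compounds named here.

Of the compounds shown here, three built on one shared core have been measured. Compound 1 `OC[C@H]1O[C@@H](n2cnc3c(NCc4cccc(Br)c4)ncnc32)[C@H](O)[C@@H]1O` gives 19700 nM in a functional assay on K562 cells (Homo sapiens) for antiproliferative activity, with a stated time of 72 h; on this read-out lower numbers stand for stronger inhibition and higher numbers for weaker inhibition. Compound 2 `COc1cccc(CNc2ncnc3c2ncn3[C@@H]2O[C@H](CO)[C@@H](O)[C@H]2O)c1O` gives 27900 nM in this assay, and compound 3 `Cc1ccc(O)c(CNc2ncnc3c2ncn3[C@@H]2O[C@H](CO)[C@@H](O)[C@H]2O)c1` gives 16500 nM. Compound 3 stands lowest of the three numbers, but its separation from the others is small: a 1.2-fold lower number from compound 1 to compound 3 (0.08 log units; within the scatter) and a 1.7-fold lower number from compound 2 to compound 3 (0.23 log units; within the scatter). The exchange between the other two is likewise small, a 1.4-fold higher number from compound 1 to compound 2 (0.15 log units; within the scatter).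

Compound 4 `OC[C@H]1O[C@@H](n2cnc3c(NCc4ccc(C(F)(F)F)cc4)ncnc32)[C@H](O)[C@@H]1O` has not yet been measured. It differs from compound 3 in a single place: 4-(trifluoromethyl)phenyl in place of 2-hydroxy-5-methylphenyl on a saturated chain carbon bound to a nitrogen on an aromatic ring. For the measured compounds named here, no measured step involves a trifluoromethyl group, so the closest guidance comes from the three exchanges of the aryl group already seen, every one of which stayed within the scatter. Compound 4 is therefore expected to show no step beyond the scatter in this assay, with a 1.2-fold higher number from compound 3 to compound 4 (0.08 log units; within the scatter). Compound 4 is estimated at 20000 nM in this assay, with a range from 8000 nM to 50000 nM.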

Compound 4, half-maximal inhibitory concentration: > 166000 nM
Compound 4 was reported as a limit; the forecaster's own chance of this, stated with the estimate: 10%; middle value at least 8.3-fold (0.91 log units) away from the limit.
By their numbers in this assay, from the lowest: compounds 3, 1 and 2 (each within the scatter of the next). At a limit, above all of these: compound 4.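

In this assay, for the compounds shown here, the aryl group on a saturated chain carbon bound to a nitrogen on an aromatic ring had so far been exchanged only within the scatter, and this change is the first to go beyond it. The step is read against all three earlier compounds: an at least 10-fold higher number from compound 3 to compound 4 (1.00 log units; beyond the scatter), an at least 5.9-fold higher number from compound 2 to compound 4 (0.77 log units; beyond the scatter) and an at least 8.4-fold higher number from compound 1 to compound 4 (0.92 log units; beyond the scatter). Compound 1 carries 3-bromophenyl, with no hydroxy group on the ring, yet it stays within the scatter of compound 2 and compound 3, so losing the hydroxy group does not alone account for the step, and the value of compound 4 is a limit, not a number: the limit of > 166000 nM in this assay, at which 1 of the 4 values shown sits.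

The compounds shown leave open whether the step belongs to the trifluoromethyl group or to its place on the ring, which a 4-bromophenyl or a 3-(trifluoromethyl)phenyl compound would separate. They also leave open how a 4-methoxyphenyl or a 4-aminophenyl group would read at this place.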